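Swapping Methoxy for Methyl on a Fused Ring System

A few compounds are considered here, and "the series" means these few. Any claim that something is new, unique, unknown or untested is made for them only; others in the source may bear on it.

Compound 1 `Cc1ccc2[nH]c(-n3cccn3)c(C3=C(Br)C(=O)NC3=O)c2c1` gives 29000 nM
Compound 2 `COc1ccc2[nH]c3c4cn[nH]c4c4c(c3c2c1)C(=O)NC4=O` gives 45000 nM

Both compounds were tested in a functional assay on Hs 683 cells (Homo sapiens) for cytotoxicity, read by MTT assay, with a stated time of 72 h (on this read-out higher numbers stand for weaker inhibition and lower numbers for stronger inhibition), and their values lie within the usual scatter of repeated measurements. Compound 2 has the higher number of the two, but this gap is too small to rank it against compound 1.

The next compound, compound 3 `Cc1ccc2[nH]c3c4cn[nH]c4c4c(c3c2c1)C(=O)NC4=O`, keeps the core of compound 2 and changes a single group: methyl in place of methoxy on an aromatic carbon. In words, this puts methyl in place of methoxy on an aromatic carbon.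

Among the measured compounds shown here, no measured pair shows this swap on its own, so its size cannot be read directly from the data. For the measured compounds named here, the only guide is that compound 1 at 29000 nM and compound 2 at 45000 nM sit close together despite their different structures. The expected step of a 1.3-fold lower number from compound 2 to compound 3 (0.11 log units; within the scatter) is estimated to stay within the scatter, with no clear direction. The estimate for compound 3 is 35000 nM (expected range 13000 nM to 90000 nM).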

Compound 3, half-maximal inhibitory concentration: > 100000 nM
Compound 3: a limit, no number (the forecaster's own chance of this, stated with the estimate: 12%); middle value at least 2.8-fold (0.45 log units) away from the limit.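

On this aromatic carbon, methyl in place of methoxy is not a neutral exchange: in this assay, the swap gives an at least 2.2-fold higher number from compound 2 to compound 3 (0.34 log units; beyond the scatter). Compound 3 gives > 100000 nM, and this value is a limit of the assay, not a number. Compound 1 and compound 2 differ in more than one place, so they could not isolate this group, whereas this single change shows that methoxy gives stronger inhibition here than methyl, though only the lower end of the step can be read from this limit: the limit of > 100000 nM in this assay, at which 1 of the 3 values shown sits.

As far as these compounds go, how much weaker compound 3 really is remains open, so the full size of the step is unknown. It is also unclear how a hydroxyl group, an amine or a longer ether such as ethoxy on this aromatic carbon would compare with methoxy, and so whether the oxygen atom or the whole methoxy group matters for the activity of compound 2.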